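Sulfonyl ring replacements on the hydroxy-amide anilide core

The source may report more compounds than this note shows. Statements on the series, on what has been measured and on what is new or still open speak of the compounds shown alone.

Compound 2 `CC(O)(C(=O)Nc1ccc(S(=O)(=O)c2cccnc2)cc1)C(F)(F)F` carries a pyridin-3-yl group on its sulfonyl sulfur. Among the compounds with values here, in a functional assay (Cavia porcellus) with sulfonylurea receptors; K-ATP channels (Homo sapiens) as the target (on this read-out higher numbers stand for weaker inhibition and lower numbers for stronger inhibition), compound 2 gives 3500 nM, the only numerical value in the set so far. Compound 1 `CC(O)(C(=O)Nc1ccc(S(=O)(=O)c2ccc(C#N)cc2)cc1)C(F)(F)F` is the 4-cyanophenyl counterpart. In this assay compound 1 gives only a limit of the assay, > 30000 nM. Within the data shown here, the single measured step is thus an at least 8.5-fold lower number from compound 1 to compound 2 (0.93 log units; beyond the scatter), a change on the sulfonyl sulfur whose true size is bounded by the limit of > 30000 nM in this assay, at which 1 of the 2 values shown sits.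

Compound 3 `CC(O)(C(=O)Nc1ccc(S(=O)(=O)c2nccs2)cc1)C(F)(F)F` is the next member: 1,3-thiazol-2-yl in place of pyridin-3-yl on a sulfonyl sulfur. Among the measured compounds shown here, no measured step exchanges one ring for another on the sulfonyl sulfur; the step from compound 1 to compound 2 shows only that the group there can move the read-out by at least a modest amount, and it offers no direction for the present exchange. In this assay the expected step is a 1.2-fold lower number from compound 2 to compound 3 (0.07 log units; within the scatter), within the scatter, with neither direction favoured. For compound 3 the estimate in this assay is 3000 nM, with a range from 800 nM to 12000 nM.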

Compound 3, half-maximal inhibitory concentration: 1400 nM
Beside the measured number, compound 3's estimate is 2.1-fold (0.33 log units) above it; the range from low to high includes it.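

In this assay, within the data shown here, the new result gives a 2.5-fold lower number from compound 2 to compound 3 (0.40 log units; beyond the scatter), the first step on the sulfonyl sulfur with a number at both ends, and it shows that a five-membered aromatic ring with 2 hetero atoms can replace a six-membered aromatic ring with 1 hetero atom there without any loss of inhibition. The other new step is an at least 21-fold lower number from compound 1 to compound 3 (1.33 log units; beyond the scatter), so among the three compounds shown both pyridin-3-yl and 1,3-thiazol-2-yl give lower numbers than 4-cyanophenyl. Compound 1 stands only at a limit of the assay, so this second step gives a bound and not a size: the limit of > 30000 nM in this assay, at which 1 of the 3 values shown sits.

Among these compounds, compound 2 and compound 3 differ at once in ring size, in the number of hetero atoms and in the presence of a ring sulfur, so the single step cannot assign the change to any one of these. Also open, from the compounds shown here alone, is how a plain phenyl ring, a thiophen-2-yl ring or a 1,3-thiazol-2-yl ring bearing a methyl group or an amine would read on the sulfonyl sulfur.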